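Sulfonamide nitrogen exchange: from compound 2 to compound 4

This account rests on a few compounds, and the source may have more. Where it says the series, first, only, none or still open, it means among the compounds named here.

Compound 2 `CN(c1ccccc1)S(=O)(=O)c1ccc(NC(=O)c2ccc(Cl)cc2Cl)cc1` holds the higher of the two numbers at hand: in a functional assay on HEK293 cells for agonist activity at probable G-protein coupled receptor 27 (Homo sapiens), read by a luciferase reporter and beta-arrestin recruitment, with a stated time of 10 min (on this read-out lower numbers stand for smaller maximal responses and higher numbers for larger maximal responses), compound 2 gives 50%. Compound 3 `O=C(Nc1ccc(S(=O)(=O)Nc2ccccc2)cc1)c1ccc(I)cc1F` gives 36% in this assay, a gap beyond the usual scatter. For compound 1 `O=C(Nc1cccc(S(=O)(=O)Nc2ccccc2)c1)c1ccc(Cl)cc1Cl` the entry in this assay reads "not determined" (no result reported), so no number is available for it.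

Compound 4 `Cc1ccccc1NS(=O)(=O)c1ccc(NC(=O)c2ccc(Cl)cc2Cl)cc1` differs from compound 2 only at the sulfonyl sulfur: (2-methylphenyl)amino in place of methyl(phenyl)amino on a sulfonyl sulfur. For the measured compounds named here, no measured pair in this set shows this change on its own, so the size of the step is open. A modest move downward, of about the scatter or a little beyond, is the working expectation, with the step from compound 2 to compound 4 estimated as a number 8 percentage points lower from compound 2 to compound 4 (within the scatter). Compound 4 is accordingly expected to give 42% in this assay, within a range from 22% to 62%.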

Compound 4, largest response reached (Emax), in percent of the reference or control that the assay uses: 32%
Compound 4: the middle estimate sits 10 percentage points above what was measured; the measured number falls inside the stated range.
By their numbers in this assay, from the lowest: compounds 4 and 3 (each within the scatter of the next); then compound 2.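

For the compounds shown here, exchanging methyl(phenyl)amino for (2-methylphenyl)amino on a sulfonyl sulfur gives the first measured step at this position in this assay, a number 18 percentage points lower from compound 2 to compound 4 (beyond the scatter). The two compounds have the same atoms, joined differently, so a rearrangement alone, with a hydrogen-bond donor gained, is enough to move the largest response beyond the scatter. Nothing at hand explains this step.

On these data alone, whether the gained donor or the new place of the methyl carries the step remains open. So does what a morpholine or a benzylamino group on the sulfonyl sulfur would give.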